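This account rests on a few compounds, and the source may have more. Where it says the series, first, only, none or still open, it means among the compounds named here.

Measured in a functional assay on MDA-MB-231 cells (Homo sapiens) for inhibition, read by MTT assay, with a stated time of 72 h (on this read-out lower numbers stand for stronger inhibition and higher numbers for weaker inhibition), so far:
- compound 1 `O=[N+]([O-])c1ccccc1Nc1nnc(-c2c[nH]c3ccccc23)o1` gives 900 nM
- compound 2 `O=[N+]([O-])c1ccc(Nc2nnc(-c3c[nH]c4ccccc34)o2)cc1` gives 3540 nM

Compound 2 stands highest of these two numbers, and compound 1 lies lower by a gap beyond the scatter. The next structure, compound 3 `Clc1ccc(Nc2nnc(-c3c[nH]c4ccccc34)o2)cc1`, has chloro in place of nitro on an aromatic carbon para to a large group. Within the data shown here, no measured pair shows this exchange, so the size of the step is uncertain. The expected 1.2-fold lower number from compound 2 to compound 3 (0.07 log units; within the scatter) in this assay is no step beyond the scatter. Compound 3 is estimated at 3000 nM with an expected range from 1000 nM to 9000 nM in this read-out.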

Compound 3, half-maximal inhibitory concentration: 9770 nM
For compound 3 the middle estimate is 3.3-fold (0.51 log units) below the measured one; measured number above the stated range.
By their numbers in this assay, from the lowest: compound 1; then compound 2; then compound 3.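

In this assay, the exchange of nitro for chloro on an aromatic carbon para to a large group is not neutral: it gives a 2.8-fold higher number from compound 2 to compound 3 (0.44 log units; beyond the scatter) and so puts nitro ahead of chloro at this place. Among these compounds, this is the first single-place step, and it shows that the group on this carbon affects the read-out. No available measurement accounts for the step. Open, as far as these compounds go, is where an amine or a carboxylic acid would fall at this place relative to nitro and chloro. Also open, from the compounds shown here alone, is whether chloro costs as much at the place nitro holds in compound 1.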